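The compounds below may be only part of what the source reports. "The series", "measured", "known", "first", "only" and "open" are said of these compounds alone.

Three compounds built on a shared thiophene ester bearing a trimethoxyphenyl amine have been tested in a functional assay on MCF7 cells (Homo sapiens) for cytotoxicity, read by MTT assay, with a stated time of 72 h; a higher number here means a weaker inhibitor, a lower number a stronger inhibitor. Compound 1 `COC(=O)c1sc2nc(C)ccc2c1Nc1cc(OC)c(OC)c(OC)c1` gives 0.53 nM, compound 2 `COC(=O)c1sc2ncccc2c1Nc1cc(OC)c(OC)c(OC)c1` gives 2640 nM, and compound 3 `COC(=O)c1sc2ccccc2c1Nc1cc(OC)c(OC)c(OC)c1` gives 795 nM. The difference between the cores of compound 2 and compound 3 is not broken down here. Between compound 2 and compound 1 one change is made, (methyl in place of hydrogen on an aromatic carbon), and it produced a 5000-fold lower number from compound 2 to compound 1 (3.70 log units; beyond the scatter). Compound 4 `COC(=O)c1sc2cccc(C)c2c1Nc1cc(OC)c(OC)c(OC)c1`, not yet measured, carries the same kind of change relative to compound 3, (methyl in place of hydrogen on an aromatic carbon); here the carbon sits in a six-membered aromatic ring of carbon only, ortho to a fused ring, rather than in a ring with one nitrogen, next to the ring nitrogen and para to a fused ring. Because compound 2 to compound 1 gave a 5000-fold lower number from compound 2 to compound 1 (3.70 log units; beyond the scatter), a drop is expected, but the different place makes its size uncertain: the step is estimated at a 13-fold lower number from compound 3 to compound 4 (1.12 log units; beyond the scatter), and compound 4 is expected to give about 60 nM, likely between 3 nM and 600 nM.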

Compound 4, half-maximal inhibitory concentration: 8190 nM
Estimate against measurement, compound 4: 140-fold (2.14 log units) below; the measured number lies above the stated range.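

On the core of compound 3, methyl in place of hydrogen on an aromatic carbon gave a 10-fold higher number from compound 3 to compound 4 (1.01 log units; beyond the scatter) in this assay, so the compound became a weaker inhibitor. The same kind of change made compound 1 far stronger than compound 2, so its effect did not carry from one core to the other: the same change on two cores in this assay, a 5000-fold lower number (3.70 log units; beyond the scatter) from compound 2 to compound 1 and a 10-fold higher number (1.01 log units; beyond the scatter) from compound 3 to compound 4, 51000-fold (4.71 log units) apart, beyond the scatter of two such steps

The methyl sits in a different place on each core, so these two pairs cannot show whether the core or the place decides the outcome, nor why the steps differ. Going by these compounds, it remains open how a methyl on the other aromatic carbons of the core of compound 3 would behave. Whether an ethyl group or an amine on the same carbon would also weaken inhibition is open too.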